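Shortening a side chain on compound 1

The source may report more compounds than this note shows. Statements on the series, on what has been measured and on what is new or still open speak of the compounds shown alone.

Measured so far:
- Compound 1 `CC(C)NC1=NS(=O)(=O)c2cc(Cl)ccc2N1`: 36.3 uM
- Compound 2 `CC(C)NC1=NS(=O)(=O)c2cc(F)ccc2N1`: 43.1 uM
- Compound 3 `C=CCNC1=Nc2ccc(F)cc2S(=O)(=O)N1`: > 300 uM, a limit

Going by the values given here, in a functional assay (aorta) with Rattus norvegicus as the target (a lower number here means that less compound is needed, a higher number that more compound is needed for the effect), compound 1 gives 36.3 uM, one of only two true numbers here. The other is close, with a 1.2-fold higher number from compound 1 to compound 2 (0.07 log units; within the scatter).

Compound 4 `CCNC1=NS(=O)(=O)c2cc(Cl)ccc2N1` keeps the core of compound 1 but has ethylamino in place of isopropylamino (hydrogen in place of methyl on a saturated chain carbon bound to an amine nitrogen and a saturated chain carbon). The halogen step does not touch this chain, and no measured step sizes the change. Among the compounds with values here, the only hint is compound 3, which reports just a limit, > 300 uM. It tilts the expectation, loosely, toward a higher number in this assay. The expected size is a 2.1-fold higher number from compound 1 to compound 4 (0.32 log units; beyond the scatter). For compound 4 the estimate is 75 uM, with an expected range of 25 uM to 250 uM.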

Compound 4, concentration for half-maximal effect: 39.9 uM
Compound 4: the middle estimate sits 1.9-fold (0.27 log units) above what was measured, and the stated range covers the measured number.
By their numbers in this assay, from the lowest: compounds 1, 4 and 2 (each within the scatter of the next). At a limit, above all of these: compound 3.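

In this assay, ethylamino in place of isopropylamino gives a 1.1-fold higher number from compound 1 to compound 4 (0.04 log units; within the scatter). The isopropylamino group of compound 1 is therefore not needed in full at this position, since one methyl can go without a step beyond the scatter. Nothing shown explains why this chain change leaves the read-out within the scatter:.

Going by these compounds, whether a longer chain, such as butylamino, or a plain amine would hold up on the same core stays open. Compound 3 gives only a limit, > 300 uM, and differs from compound 1 in more than one place, so it does not size this step.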